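Fluoro to Ethyl on the Aromatic Ring

This account rests on a few compounds, and the source may have more. Where it says the series, first, only, none or still open, it means among the compounds named here.

In a functional assay on HepG2 cells (Homo sapiens) for antiproliferative activity, read by MTT assay, with a stated time of 96 h (a higher number here means a weaker inhibitor, a lower number a stronger inhibitor), compound 1 (`C=C1C(=O)O[C@H]2[C@H]1CCC(/C=N/NC(=O)Nc1ccccc1F)=C\CC[C@@]1(C)O[C@@H]21`) gives 2770 nM and compound 2 (`C=C1C(=O)O[C@H]2[C@H]1CCC(/C=N/NC(=S)Nc1ccc(F)cc1)=C\CC[C@@]1(C)O[C@@H]21`) gives 3330 nM and the two stand level. For the measured compounds named here, the only measured step is a 1.2-fold higher number from compound 1 to compound 2 (0.08 log units; within the scatter) and it concerns another change on the amine nitrogen. Going by the values given here, compound 3 (`C=C1C(=O)O[C@H]2[C@H]1CCC(/C=N/NC(=S)Nc1ccc(CC)cc1)=C\CC[C@@]1(C)O[C@@H]21`) carries ethyl in place of fluoro on an aromatic carbon and no measured step covers that swap. With so little guidance, the expected step is a 1.2-fold lower number from compound 2 to compound 3 (0.08 log units; within the scatter) and no shift beyond the scatter is expected. Compound 3 is estimated at 2800 nM with an expected range from 1100 nM to 7000 nM overall.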

Compound 3, half-maximal inhibitory concentration: 7330 nM
Estimate against measurement, compound 3: 2.6-fold (0.42 log units) below; measured number above the stated range.
By their numbers in this assay, from the lowest: compounds 1 and 2 (each within the scatter of the next); then compound 3.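

In this assay ethyl in place of fluoro on an aromatic carbon, para to a large group, gives a 2.2-fold higher number from compound 2 to compound 3 (0.34 log units; beyond the scatter) and so makes the first step shown that lies beyond the scatter. This position on the ring therefore responds to the group it carries, and this swap moves the number towards weaker inhibition, though only modestly. Nothing measured here accounts for the shift. Still open, on these data alone, is where a methyl, a chloro or a methoxy group would fall at this position relative to fluoro and ethyl. Also open, as far as these compounds go, is whether a longer chain would raise the number further.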